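This account rests on a few compounds, and the source may have more. Where it says the series, first, only, none or still open, it means among the compounds named here.

Measured compounds:
Compound 1, `Cc1ccc(COc2ccc(-c3nn(CCC#N)c(=S)o3)cc2)cc1`: 400 nM in an assay for inhibition of Amine oxidase [flavin-containing] B (Rattus norvegicus); on this read-out lower numbers stand for stronger inhibition and higher numbers for weaker inhibition
Compound 2, `N#CCCn1nc(-c2ccc(OCc3cccc(Cl)c3)cc2)oc1=S`: 160 nM in this assay
Compound 3, `Cc1ccc(COc2ccc(C3=NN(CCC#N)C(=O)CO3)cc2)cc1`: 320 nM in this assay

Compound 1 and compound 2 share a core and differ by 3-chlorophenyl in place of 4-methylphenyl on a saturated chain carbon bound to an oxygen on an aromatic ring. That change gave a 2.5-fold lower number from compound 1 to compound 2 (0.40 log units; beyond the scatter). Compound 3 carries a different core; the difference between the two cores is not broken down here. Compound 4, `N#CCCN1N=C(c2ccc(OCc3cccc(Cl)c3)cc2)OCC1=O`, has not yet been measured and differs from compound 3 by 3-chlorophenyl in place of 4-methylphenyl on a saturated chain carbon bound to an oxygen on an aromatic ring, the same change as from compound 1 to compound 2, at the same place. Because the earlier step was a 2.5-fold lower number from compound 1 to compound 2 (0.40 log units; beyond the scatter), compound 4 is expected to show a step of about a 2.3-fold lower number from compound 3 to compound 4 (0.36 log units; beyond the scatter). Compound 4 is accordingly estimated at 140 nM in this assay, with a likely range from 60 nM to 330 nM.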

Compound 4, half-maximal inhibitory concentration: 13 nM
Estimate against measurement, compound 4: 11-fold (1.03 log units) above; measured number below the stated range.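

In this assay, the change from 4-methylphenyl to 3-chlorophenyl gave a 25-fold lower number from compound 3 to compound 4 (1.39 log units; beyond the scatter), so the direction carried over from one core to the other but the size did not: the same change on two cores in this assay, a 2.5-fold lower number (0.40 log units; beyond the scatter) from compound 1 to compound 2 and a 25-fold lower number (1.39 log units; beyond the scatter) from compound 3 to compound 4, 9.8-fold (0.99 log units) apart, beyond the scatter of two such steps

The step seen on the core of compound 1 was therefore a poor guide to the size of the step on the core of compound 3. With a single pair on each core, this does not show why the two steps differ, or how any other change would carry between these cores.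

Going by these compounds, whether a plain phenyl or a fluorophenyl in this place would show the same gap between the cores remains open. So does the outcome of replacing the nitrile with an amine.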